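Turning Methoxy into Ethoxy in a Small Series

The compounds below may be only part of what the source reports. "The series", "measured", "known", "first", "only" and "open" are said of these compounds alone.

In a functional assay on MCF7 cells (Homo sapiens) for antiproliferative activity, read by MTT assay, with a stated time of 72 h (on this read-out lower numbers stand for stronger inhibition and higher numbers for weaker inhibition), three compounds with a shared core differ in one group. Compound 1 `CNc1nc(-c2cc(OC)c(OC)c(OC)c2)c(-c2ccc(C)cc2)s1` with methyl gives 10.1 nM and compound 2 `CNc1nc(-c2cc(OC)c(OC)c(OC)c2)c(-c2ccc(C(F)(F)F)cc2)s1` with trifluoromethyl gives 7290 nM while compound 3 `CNc1nc(-c2cc(OC)c(OC)c(OC)c2)c(-c2ccc(OC)cc2)s1` with methoxy gives 37.6 nM and so holds the middle of the three numbers. Replacing methyl with trifluoromethyl made a large step (a 720-fold higher number from compound 1 to compound 2 (2.86 log units; beyond the scatter)) and so did replacing trifluoromethyl with methoxy (a 190-fold lower number from compound 2 to compound 3 (2.29 log units; beyond the scatter)). Replacing methyl with methoxy made only a modest one (a 3.7-fold higher number from compound 1 to compound 3 (0.57 log units; beyond the scatter)).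

Compound 4 `CCOc1ccc(-c2sc(NC)nc2-c2cc(OC)c(OC)c(OC)c2)cc1` is still unmeasured. It turns methoxy into ethoxy (methyl in place of hydrogen on a saturated chain carbon bound to an oxygen on an aromatic ring) with methyl in place of hydrogen on a saturated chain carbon bound to an oxygen on an aromatic ring. For the measured compounds named here, no measured step makes this exact change, so the modest methyl-to-methoxy step is the closest guide, while the two large steps argue for a wide range. A modest move to a higher number in this assay is expected (a 1.6-fold higher number from compound 3 to compound 4 (0.20 log units; within the scatter)) for this small addition. Compound 4 is estimated at 60 nM (expected range 15 nM to 250 nM).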

Compound 4, half-maximal inhibitory concentration: 24.5 nM
Beside the measured number, compound 4's estimate is 2.4-fold (0.39 log units) above it; the range from low to high includes it.
By their numbers in this assay, from the lowest: compound 1; then compounds 4 and 3 (each within the scatter of the next); then compound 2.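

Extending methoxy to ethoxy at this spot gives a 1.5-fold lower number from compound 3 to compound 4 (0.19 log units; within the scatter), so in this assay the two groups cannot be told apart, and the added methyl on the chain carbon bound to the oxygen is tolerated. The ethoxy group also keeps the picture set by the earlier groups, with a 2.4-fold higher number from compound 1 to compound 4 (0.38 log units; beyond the scatter) still a modest gap and a 300-fold lower number from compound 2 to compound 4 (2.47 log units; beyond the scatter) as large as the earlier steps involving trifluoromethyl, which remains the only group shown with a number far from the others. Nothing in the data shown gives a reason for these numbers.

On these data alone, whether a longer chain such as propoxy or butoxy would stay at this level remains open, as does the effect of a hydroxyl group here. Also open, as far as these compounds go, is whether a chlorine or a nitrile would give a number as high as trifluoromethyl does.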